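This account rests on a few compounds, and the source may have more. Where it says the series, first, only, none or still open, it means among the compounds named here.

Of the compounds shown here, three sharing one core have been measured in an assay on cells for inhibition of MAP kinase-interacting serine/threonine-protein kinase 1 (Homo sapiens), read by mobility shift assay, with stated times of 10 min and 60 min, in the presence of a further agent that is not named here; a lower number here means a stronger inhibitor, a higher number a weaker inhibitor. Compound 1 `CCOc1cc(-c2cccnc2)ccc1C(N)=O` gives 2200 nM. Compound 2 `NC(=O)c1ccc(-c2cccnc2)cc1OC1CCNCC1`, which carries a piperidin-4-yl in place of the ethyl on the ring oxygen, gives 1100 nM; a 2.0-fold lower number from compound 1 to compound 2 (0.30 log units; within the scatter). Compound 3 `NC(=O)c1ccc(-c2cccnc2)cc1Cl`, with a chloro on the aromatic carbon that holds the oxygen in the other two, gives 11000 nM, the highest of the three numbers, so compound 3 stands as the weakest inhibitor of the set. Both steps toward it are beyond the scatter: a 5.0-fold higher number from compound 1 to compound 3 (0.70 log units; beyond the scatter) and a 10-fold higher number from compound 2 to compound 3 (1.00 log units; beyond the scatter).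

Compound 4 `NC(=O)c1ccc(-c2cccnc2)cc1OC1CCCCC1` is not yet measured. It differs from compound 3 in one place: cyclohexyloxy in place of chloro on an aromatic carbon. This change runs opposite to the two steps that end at compound 3, where an ethoxy or a (piperidin-4-yl)oxy gave way to chloro and the number rose by a modest amount each time. Returning an oxygen-linked group in place of the chloro is therefore expected to bring the number down by a similar, modest amount, with the cyclohexyloxy likely landing between the two oxygen groups already seen. The estimated step is a 7.3-fold lower number from compound 3 to compound 4 (0.87 log units; beyond the scatter). Compound 4 is thus expected to give about 1500 nM, with a likely range from 600 nM to 5000 nM.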

Compound 4, half-maximal inhibitory concentration: 1500 nM
Compound 4: the middle estimate sits on the measured number at the digits printed, and the stated range covers the measured number.
By their numbers in this assay, from the lowest: compounds 2, 4 and 1 (each within the scatter of the next); then compound 3.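

At this position, on an aromatic carbon ortho to the carbamoyl group, the result gives a third oxygen-linked group to set against chloro, with a 7.3-fold lower number from compound 3 to compound 4 (0.87 log units; beyond the scatter) as the step away from it. In this assay the group on the oxygen now shows no clear effect across three quite different choices, with a 1.4-fold higher number from compound 2 to compound 4 (0.13 log units; within the scatter) and a 1.5-fold lower number from compound 1 to compound 4 (0.17 log units; within the scatter) both lying within the usual scatter, so a chain, a ring of carbon only and a ring with nitrogen cannot be told apart. The new piece of information is that the nitrogen of the piperidin-4-yl is not needed to reach this level, since the ring of carbon only sits with it in the same range.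

These compounds leave open whether the oxygen link itself matters, which a methylene or an amine nitrogen in its place could test, and whether a phenyl or a small methyl on the oxygen would also stay in the same range. They also leave open why the oxygen-linked groups differ from chloro, and no measurement here addresses that point.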